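Compound 1 to compound 3: pent-1-en-1-yl in place of methyl

The compounds below may be only part of what the source reports. "The series", "measured", "known", "first", "only" and "open" are said of these compounds alone.

In a functional assay on HepG2 cells (Homo sapiens) for cytotoxicity, read by WST assay, with a stated time of 24 h (a lower number here means that less compound is tolerated, a higher number that more compound is tolerated), compound 1 (`Cc1cc(-c2ccc3cc(CO)ccc3c2)ccc1O`) gives > 32 ug/mL as a limit, not a number. Compound 2 (`Cc1cc(-c2ccc3cc(C(=O)O)ccc3c2)ccc1O`) gives > 32 ug/mL as a limit too. Within the data shown here, the series so far shows the limit of > 32 ug/mL in this assay, at which 2 of the 2 values shown sit, and no readable number. Compound 3 (`CCCC=Cc1cc(-c2ccc3cc(CO)ccc3c2)ccc1O`) carries pent-1-en-1-yl in place of methyl on an aromatic carbon as its change from compound 1. Among the measured compounds shown here, the one measured step, a step that the two limits leave unreadable from compound 1 to compound 2 in this series, is a different change and offers no size to carry over. A step toward lower numbers in this assay is expected on the structural change alone, with an at least 1.3-fold lower number from compound 1 to compound 3 (0.12 log units; that floor lies within the scatter) as the estimated step, though on thin support. Compound 3 is estimated at 24 ug/mL with an expected range from 10 ug/mL to 50 ug/mL for now.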

Compound 3, concentration lethal to 50% of the cells: 3.89 ug/mL
Estimate against measurement, compound 3: 6.2-fold (0.79 log units) above, outside the stated range (below it).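

In this assay, among these compounds, pent-1-en-1-yl in place of methyl, ortho to a hydroxy group, gives the first readable number, with an at least 8.2-fold lower number from compound 1 to compound 3 (0.91 log units; beyond the scatter) as the step. This position therefore moves the read-out, while the step between the hydroxymethyl and carboxy compounds cannot be read. The figure for compound 1 is a limit, so the step has only a floor, and the series still sits largely at that limit: the limit of > 32 ug/mL in this assay, at which 2 of the 3 values shown sit.

Whether the double bond or the chain length carries the step stays open, since a saturated pentyl chain and a shorter propyl chain are not among the compounds shown. Also open, going by these compounds, is how an amine or a carboxylic acid at the end of this chain would read.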